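Ortho-Cyano on the Phenylpiperazine: What to Expect

This account rests on a few compounds, and the source may have more. Where it says the series, first, only, none or still open, it means among the compounds named here.

Compound 1 `COc1ccccc1N1CCN(CCCNc2ncccc2C(=O)N(C)C)CC1`: 20 nM
Compound 2 `COc1ccccc1N1CCN(CCCSc2ccccc2C(=O)N(C)C)CC1`: 12.6 nM
Compound 3 `CN(C)C(=O)c1cccnc1NCCCN1CCN(c2ccccc2)CC1`: 15.9 nM

In a functional assay on aorta for antagonist activity at Alpha-1D adrenergic receptor (Rattus norvegicus) (on this read-out lower numbers stand for tighter binding and higher numbers for weaker binding), compound 3 gives 15.9 nM, the second highest of the three numbers. Its nearest neighbour is compound 1 at 20 nM, and the furthest is compound 2 at 12.6 nM; both gaps are within the scatter, so the three compounds cannot be told apart on this read-out.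

Compound 4 `CN(C)C(=O)c1cccnc1NCCCN1CCN(c2ccccc2C#N)CC1` has not been measured. It differs from compound 3 by cyano in place of hydrogen on an aromatic carbon. For the measured compounds named here, the only measured step that touches the same ring is a 1.3-fold lower number from compound 1 to compound 3 (0.10 log units; within the scatter), which shows that removing a methoxy from that ring left the number essentially unchanged. Going by the values given here, no measured pair shows the effect of a cyano group anywhere, so the bearing of that step is indirect. Since every change seen so far in this assay stayed within the scatter, compound 4 is expected to stay close to compound 3, with a step of about a 1.0-fold higher number from compound 3 to compound 4 (0.00 log units; within the scatter). The estimate for compound 4 is 16 nM, with a range from 5 nM to 50 nM.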

Compound 4, dissociation constant: 10 nM
Compound 4: the middle estimate sits 1.6-fold (0.20 log units) above what was measured; the range from low to high includes it.
By their numbers in this assay, from the lowest: compounds 4, 2, 3 and 1 (each within the scatter of the next).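

In this assay, for the compounds shown here, the first cyano group gives a 1.6-fold lower number from compound 3 to compound 4 (0.20 log units; within the scatter), so this place, ortho to a large group, takes a cyano group in place of hydrogen with no change that can be told from the scatter. Cyano in place of methoxy at the same place gives a 2.0-fold lower number from compound 1 to compound 4 (0.30 log units; within the scatter) and also stays within the scatter, so hydrogen, methoxy and cyano cannot be told apart there on this read-out. Nothing available here explains this flat picture.

Still open, on these data alone, is whether an amine, a carboxylic acid or a longer chain at this place would stay as close to compound 3. Also open, as far as these compounds go, is whether cyano would give the same picture on the core of compound 2.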